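The compounds below may be only part of what the source reports. "The series", "measured", "known", "first", "only" and "open" are said of these compounds alone.

Three related compounds have been tested in an assay on isolated protein for inhibition of phosphatidylinositol 4,5-bisphosphate 3-kinase catalytic subunit beta isoform (Homo sapiens), read by 33P incorporation, with a stated time of 60 min; a lower number here means a stronger inhibitor, a higher number a weaker inhibitor. Compound 1, `Cc1ccc([N+](=O)[O-])cc1S(=O)(=O)N(C)/N=C/c1cnn2ccccc12`, reaches only a limit of the assay, giving > 10000 nM. Compound 2, `COc1ccn2ncc(/C=N/N(C)S(=O)(=O)c3cc([N+](=O)[O-])ccc3C)c2c1`, carries a methoxy in place of hydrogen on an aromatic carbon, and compound 2 also gives only a limit, > 1000 nM. Compound 3, `Cc1ccc([N+](=O)[O-])cc1S(=O)(=O)N(C)/N=C/c1cnn2cc(Br)ccc12`, carries a bromo in place of hydrogen on an aromatic carbon, and compound 3 likewise gives only a limit, > 1000 nM. Compound 3 therefore stands on a limit, as do both other values shown, so the steps a step that the two limits leave unreadable from compound 1 to compound 2 and a step that the two limits leave unreadable from compound 1 to compound 3 cannot be sized. Compound 4, `Cc1ccc2c(/C=N/N(C)S(=O)(=O)c3cc([N+](=O)[O-])ccc3C)cnn2c1`, differs from compound 3 by methyl in place of bromo on an aromatic carbon. Among the compounds with values here, no measured step involves this exchange, so nothing here tells how large it should be. Compound 3 sits at the limit (the limit of > 1000 nM in this assay, at which 2 of the 3 values shown sit). Compound 4 is therefore expected to stay near that limit, and the step that the limit leaves unreadable from compound 3 to compound 4 is expected to lie within the scatter. For compound 4 the estimate in this assay is 3000 nM, within a range from 1000 nM to 20000 nM.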

Compound 4, half-maximal inhibitory concentration: > 1000 nM
Compound 4 was reported as a limit (the forecaster's own chance of this, stated with the estimate: 70%); the middle value lies beyond the limit too.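

Within the data shown here, compound 4 gives only a limit of the assay, just as compound 1 and compound 3 do, so neither the step to compound 4 from compound 3 nor the one from compound 1 can be read. The compounds shown leave open how strongly any of them inhibits, and whether hydrogen, methoxy, bromo or methyl on an aromatic carbon makes any difference.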